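Swapping the aryl group on compound 3

A few compounds are considered here, and "the series" means these few. Any claim that something is new, unique, unknown or untested is made for them only; others in the source may bear on it.

In a functional assay on DU-145 cells (Homo sapiens) for inhibition, read by trypan blue exclusion, with a stated time of 96 h (on this read-out lower numbers stand for stronger inhibition of growth and higher numbers for weaker inhibition of growth), compound 1 `COc1ccccc1/C=C(/SCc1ccc(Cl)cc1)C(=O)c1ccc(Cl)cc1` gives 1000 nM. Compound 2 `O=C(/C(=C\c1c(O)cc(O)cc1O)SCc1ccc(Cl)cc1)c1ccc(Cl)cc1` gives only a limit, > 100000 nM. Compound 3 `CN(C)c1ccc(/C=C(/SCc2ccc(Cl)cc2)C(=O)c2ccc(Cl)cc2)cc1` also gives only a limit, > 100000 nM. Compound 4 `O=C(/C(=C\c1cccc(Cl)c1Cl)SCc1ccc(Cl)cc1)c1ccc(Cl)cc1` differs from compound 3 by a single change: 2,3-dichlorophenyl in place of 4-(dimethylamino)phenyl on a double-bonded chain carbon bound to a double-bonded chain carbon. Two measured steps at this same place bear on it: an at least 100-fold higher number from compound 1 to compound 2 (2.00 log units; beyond the scatter) and an at least 100-fold higher number from compound 1 to compound 3 (2.00 log units; beyond the scatter). Both are large, so the group here can move the number strongly. Compound 1 is the only one of the three with a true number, 1000 nM, so a sizeable drop is expected. The expected step is an at least 20-fold lower number from compound 3 to compound 4 (1.30 log units; beyond the scatter), towards stronger inhibition of growth. For compound 4 the estimate is 5000 nM, with an expected range from 500 nM to 60000 nM.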

Compound 4, concentration for 50% growth inhibition: 10000 nM
Compound 4: middle estimate off by 2.0-fold (0.30 log units), on the low side, and the stated range covers the measured number.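

Compound 4 shows that a group other than 2-methoxyphenyl can give a true number at this place in this assay and brings an at least 10-fold lower number from compound 3 to compound 4 (1.00 log units; beyond the scatter) and an at least 10-fold lower number from compound 2 to compound 4 (1.00 log units; beyond the scatter) as well. The 2-methoxyphenyl group still holds the better result, with a 10-fold higher number from compound 1 to compound 4 (1.00 log units; beyond the scatter) on this swap. The first two steps give only minimum sizes: the limit of > 100000 nM in this assay, at which 2 of the 4 values shown sit.

Which feature of these rings sets the number remains open. A plain phenyl or a phenyl carrying a single chlorine would be the simplest groups to compare at this place.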